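A few compounds are considered here, and "the series" means these few. Any claim that something is new, unique, unknown or untested is made for them only; others in the source may bear on it.

Measured set in a functional assay on MIA PaCa-2 cells (Homo sapiens) for inhibition, read by MTT assay, with a stated time of 7 days; on this read-out higher numbers stand for weaker inhibition and lower numbers for stronger inhibition:
compound 1 `CCC(CC)S(=O)(=O)c1ccc(S(=O)(=O)N2CCC[C@@H](C(=O)N3CCC(F)(F)CC3)C2)cc1` gives 13 nM
compound 2 `CC(C)S(=O)(=O)c1ccc(S(=O)(=O)N2CCC[C@@H](C(=O)N3CCC(F)(F)CC3)C2)cc1` gives 11 nM
compound 3 `O=C([C@@H]1CCCN(S(=O)(=O)c2ccc(S(=O)(=O)C3CC3)cc2)C1)N1CCC(F)(F)CC1` gives 26 nM

Compound 3 shows the highest of the three numbers; the step of a 2.0-fold higher number from compound 1 to compound 3 (0.30 log units; within the scatter) stays within the scatter, while a 2.4-fold higher number from compound 2 to compound 3 (0.37 log units; beyond the scatter) is modest but beyond it. Compound 4 `CC(C)NS(=O)(=O)c1ccc(S(=O)(=O)N2CCC[C@@H](C(=O)N3CCC(F)(F)CC3)C2)cc1` arises from compound 3 by isopropylamino in place of cyclopropyl on a sulfonyl sulfur. For the measured compounds named here, the steps that bear on this position are a 1.2-fold lower number from compound 1 to compound 2 (0.07 log units; within the scatter) together with the two just named, all small: exchanging one alkyl group for another on the sulfonyl sulfur has shifted the numbers little. Going by the values given here, the entering isopropylamino group brings a hydrogen-bond donor, a feature no measured step covers, so the uncertainty is wider than for those alkyl exchanges. For compound 4 the expected step is a 1.3-fold higher number from compound 3 to compound 4 (0.13 log units; within the scatter), not beyond the scatter, with an estimate of 35 nM (range 10 nM to 120 nM).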

Compound 4, half-maximal inhibitory concentration: 350 nM
Compound 4: middle estimate off by 10-fold (1.00 log units), on the low side, outside the stated range (above it).
By their numbers in this assay, from the lowest: compounds 2, 1 and 3 (each within the scatter of the next, the first and the last beyond it); then compound 4.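

On the sulfonyl sulfur in this assay, the alkyl groups interchange with small steps, but isopropylamino does not fit that picture: all three steps to it are large (a 13-fold higher number from compound 3 to compound 4 (1.13 log units; beyond the scatter); a 27-fold higher number from compound 1 to compound 4 (1.43 log units; beyond the scatter)). The closest comparison keeps the isopropyl group and adds only the amino nitrogen, and it still gives a large step (a 32-fold higher number from compound 2 to compound 4 (1.50 log units; beyond the scatter)). Nothing measured here accounts for this loss.

Still open, from the compounds shown here alone, is whether the loss follows the amino nitrogen or the hydrogen on it. Dimethylamino or pyrrolidin-1-yl on the sulfonyl sulfur would separate the two.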